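The source may hold more compounds than are shown below. What is called first, only, known or untested is meant among the compounds shown, and "the series" means these compounds.

Three anilides on a shared core have been run in a functional assay on MCF7 cells (Homo sapiens) for antiproliferative activity, read by CCK-8 assay, with a stated time of 72 h; on this read-out higher numbers stand for weaker inhibition and lower numbers for stronger inhibition. Compound 1 `O=C(Nc1cccc(-c2oc3cc(-c4ccc(F)cc4)ccc3c(=O)c2O)c1)c1ccc(F)cc1` gives 8590 nM. Compound 2 `O=C(Nc1cccc(-c2oc3cc(-c4ccc(F)cc4)ccc3c(=O)c2O)c1)c1ccc(C(F)(F)F)cc1` gives 32600 nM, the highest number of the three. Compound 3 `CCc1ccc(C(=O)Nc2cccc(-c3oc4cc(-c5ccc(F)cc5)ccc4c(=O)c3O)c2)cc1` gives 22800 nM. The measured steps read a 3.8-fold higher number from compound 1 to compound 2 (0.58 log units; beyond the scatter) and a 2.7-fold higher number from compound 1 to compound 3 (0.42 log units; beyond the scatter), while a 1.4-fold lower number from compound 2 to compound 3 (0.16 log units; within the scatter). Compound 4 `COc1cc(OC)cc(C(=O)Nc2cccc(-c3oc4cc(-c5ccc(F)cc5)ccc4c(=O)c3O)c2)c1` is not yet measured; it differs from compound 2 by 3,5-dimethoxyphenyl in place of 4-(trifluoromethyl)phenyl on a carbonyl carbon. Among the compounds with values here, the steps that bear on this exchange of the benzamide aryl group are a 3.8-fold higher number from compound 1 to compound 2 (0.58 log units; beyond the scatter) and a 1.4-fold lower number from compound 2 to compound 3 (0.16 log units; within the scatter), both modest. Because a 3.8-fold higher number from compound 1 to compound 2 (0.58 log units; beyond the scatter) and a 1.4-fold lower number from compound 2 to compound 3 (0.16 log units; within the scatter) stay modest, compound 4 is expected to move by a 1.8-fold lower number from compound 2 to compound 4 (0.26 log units; within the scatter), most likely toward a lower number. The estimate for compound 4 is 18000 nM, with a range from 6000 nM to 55000 nM.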

Compound 4, half-maximal inhibitory concentration: 3470 nM
For compound 4 the middle estimate is 5.2-fold (0.71 log units) above the measured one; measured number outside the range, below it.
By their numbers in this assay, from the lowest: compound 4; then compound 1; then compounds 3 and 2 (each within the scatter of the next).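

In this assay, within the data shown here, the aryl group on the carbonyl carbon spans a wider range than the earlier compounds showed: 3,5-dimethoxyphenyl gives a 9.4-fold lower number from compound 2 to compound 4 (0.97 log units; beyond the scatter) and a 6.6-fold lower number from compound 3 to compound 4 (0.82 log units; beyond the scatter) in this series. It also goes past the lowest earlier number, with a 2.5-fold lower number from compound 1 to compound 4 (0.39 log units; beyond the scatter) as the step, so compound 4 now stands lowest of the set. No measurement at hand accounts for these steps.

The compounds shown leave open whether a single methoxy group would read like the pair. Going by these compounds, how an amine or a carboxylic acid on this aryl group would read also stays open.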